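The source may hold more compounds than are shown below. What is called first, only, known or untested is meant among the compounds shown, and "the series" means these compounds.

Compound 1, with the structure `CCCn1c(=O)[nH]c2nc(-c3ccc(S(=O)(=O)N4CCN(c5ccccc5Br)CC4)cc3)[nH]c2c1=O`, and compound 2, with the structure `CCCn1c(=O)[nH]c2nc(-c3ccc(S(=O)(=O)N4CCN(c5ccc(C)cc5)CC4)cc3)[nH]c2c1=O`, share one core and differ only in the group on the ring amine nitrogen. In an assay on CHO cells for displacement of a labelled ligand from adenosine receptor A1 (Homo sapiens), read by scintillation counting, with a stated time of 90 min, in the presence of a further agent that is not named here (a lower number here means a stronger inhibitor, a higher number a weaker inhibitor), compound 1 gives > 1000 nM, which is a limit of the assay and not a number. In this assay compound 2 likewise gives > 1000 nM, again a limit. The step that the two limits leave unreadable from compound 1 to compound 2 therefore cannot be sized, because both values sit at the limit of > 1000 nM in this assay, at which 2 of the 2 values shown sit. Compound 2 thus stands only at a limit, with no number to place it against anything else.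

Compound 3, with the structure `CCCn1c(=O)[nH]c2nc(-c3ccc(S(=O)(=O)N4CCN(Cc5ccc(Br)cc5)CC4)cc3)[nH]c2c1=O`, differs from compound 2 by 4-bromobenzyl in place of 4-methylphenyl on an amine nitrogen in a ring. Of the measured steps only the unreadable one from compound 1 to compound 2 touches this position, and it gives no size. Within the data shown here, no measured step in this assay therefore shows whether a change on this ring nitrogen moves the value at all. The expectation for compound 3 is that it again falls near the limit, so the estimated step that the limit leaves unreadable from compound 2 to compound 3 is essentially none. Compound 3 is estimated at 2000 nM, in a range from 400 nM to 10000 nM.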

Compound 3, inhibition constant: > 1000 nM
Compound 3 ended at the assay's limit; the forecaster's own chance of this, stated with the estimate: 65%; the middle value is on the limit's open side.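

In this assay compound 3 gives > 1000 nM as a limit of the assay and not a number. Among these compounds, no step among compound 1, compound 2 and compound 3 can be read, because all three values sit at one limit: (the limit of > 1000 nM in this assay, at which 3 of the 3 values shown sit). The compounds shown leave open whether any group on this ring amine nitrogen changes the value at all.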